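Benzyl in Place of Methyl on Selenium, Quinoline Amides Kept

This account rests on a few compounds, and the source may have more. Where it says the series, first, only, none or still open, it means among the compounds named here.

The three measured compounds, all tested in a functional assay on MCF7 cells (Homo sapiens) for cytotoxicity, read by MTT assay, with a stated time of 72 h; on this read-out higher numbers stand for weaker inhibition of growth and lower numbers for stronger inhibition of growth:

Compound 1, `O=C(/N=C(/NC(=O)c1cccs1)[Se]Cc1ccccc1)c1cccs1`, gives 72500 nM.
Compound 2, `O=C(/N=C(/NC(=O)c1ccco1)[Se]Cc1ccccc1)c1ccco1`, gives 8800 nM.
Compound 3, `C[Se]/C(=N\C(=O)c1cnc2ccccc2c1)NC(=O)c1cnc2ccccc2c1`, gives 660 nM.

Compound 3 holds the lowest number of the three in this assay, and both of its gaps, to compound 2 and to compound 1, are beyond the usual scatter, so it counts as the strongest growth inhibitor in this set. All three share the same acylselenourea core; compound 3 differs from the other two both in its amide aromatic groups and in the group on selenium, so no single change links it to them.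

The next compound, compound 4, `O=C(/N=C(/NC(=O)c1cnc2ccccc2c1)[Se]Cc1ccccc1)c1cnc2ccccc2c1`, keeps the amides of compound 3 and changes only the selenium substituent: phenyl in place of hydrogen on a saturated chain carbon bound to a selenium atom. Among the measured compounds shown here, no measured pair shows what this change does on its own. Compounds 1 and 2 already carry the benzyl group, and their higher numbers come with different amides, so they do not settle the question. The expected step is therefore modest, in either direction, and may not exceed the scatter; the expected size is a 1.7-fold higher number from compound 3 to compound 4 (0.22 log units; within the scatter). On that basis compound 4 is estimated at 1100 nM, with a range from 250 nM to 4500 nM.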

Compound 4, concentration for 50% growth inhibition: 23600 nM
The estimate for compound 4 lay 21-fold (1.33 log units) below the measured number; measured number outside the range, above it.
By their numbers in this assay, from the lowest: compound 3; then compound 2; then compound 4; then compound 1.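

In this assay, the change from methyl to benzyl on selenium, with the amides of compound 3 left as they are, gives a 36-fold higher number from compound 3 to compound 4 (1.55 log units; beyond the scatter) and so counts as a large step. Among the compounds shown here, this is the first comparison in the set that differs in one place only, and it shows that this position is not indifferent: phenyl in place of hydrogen on a saturated chain carbon bound to a selenium atom costs much of the growth inhibition seen with methyl. No measurement at hand explains why this added phenyl has so large an effect on the number.

The compounds shown leave open how the number behaves between these two groups, for instance with an ethyl group or a longer chain on selenium, and whether a benzyl group carrying an amine or a hydroxyl would fare any better. They also leave open whether methyl would beat benzyl with other amides, since compound 1 and compound 2 have no methyl partner here.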